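Phenyl for Hydroxy-Methoxyphenyl: Expected Cytotoxicity on Vero Cells

The source may report more compounds than this note shows. Statements on the series, on what has been measured and on what is new or still open speak of the compounds shown alone.

Going by the values given here, compound 2 `COc1ccc(C2CC(c3cc4ccccc4o3)=NN2C(=O)c2ccncc2)c(O)c1` is one of two compounds measured in an ADME assay on Vero cells (Chlorocebus sabaeus) for cytotoxicity, read by MTT assay, with a stated time of 72 h; on this read-out higher numbers stand for weaker inhibition and lower numbers for stronger inhibition. In this assay compound 2 gives > 190000 nM, which is a limit of the assay rather than a number. Compound 1 `CN(C)c1ccc(C2CC(c3cc4ccccc4o3)=NN2C(=O)c2ccncc2)cc1` gives in this assay > 210000 nM, likewise a limit of the assay. Between these two compounds stands a step that the two limits leave unreadable from compound 1 to compound 2; both values sit at limits, as seen in the limit of > 190000 nM in this assay, at which 1 of the 2 values shown sits, and (the limit of > 210000 nM in this assay, at which 1 of the 2 values shown sits), so its size is not known. Compound 3 `O=C(c1ccncc1)N1N=C(c2cc3ccccc3o2)CC1c1ccccc1` is not yet measured. It differs from compound 2 by phenyl in place of 2-hydroxy-4-methoxyphenyl on a saturated ring carbon. Among the compounds with values here, the only measured step that bears on this change is a step that the two limits leave unreadable from compound 1 to compound 2, so no direction or size can be read from it, and no change beyond the scatter is expected. Compound 3 is therefore expected to give about 200000 nM, within 60000 nM to 250000 nM, in this assay, most likely again as a limit. That estimate corresponds to an expected step that the limit leaves unreadable from compound 2 to compound 3.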

Compound 3, half-maximal inhibitory concentration: > 209000 nM
Compound 3: only a limit was reported (the forecaster's own chance of this, stated with the estimate: 80%); middle value at least 1.0-fold (0.01 log units) from the limit.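

In this assay, going by these compounds alone, compound 1, compound 2 and compound 3 are all reported only as limits of the assay, and no step among them can be read. The compounds shown leave open where the true values lie and whether any of these changes shifts them at all.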